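Chlorophenyl placement swap on the acylated core

This account rests on a few compounds, and the source may have more. Where it says the series, first, only, none or still open, it means among the compounds named here.

Compound 1 `O=C(Nc1ccccc1C(F)(F)F)C1CCc2ccccc2N1C(=O)c1cccc(Cl)c1` holds the lowest of the two numbers seen so far: in a functional assay on PC-3 cells (Homo sapiens) for cytotoxicity, read by sulforhodamine B assay, with a stated time of 72 h (on this read-out higher numbers stand for weaker inhibition of growth and lower numbers for stronger inhibition of growth), compound 1 gives 729 nM, whereas compound 2 `O=C(Nc1ccccc1)C1CCc2ccccc2N1` gives 110000 nM in this assay, a gap well beyond the scatter. Compound 3 `O=C(Nc1ccccc1C(F)(F)F)C1CCc2ccccc2N1C(=O)c1ccccc1Cl` differs from compound 1 only by 2-chlorophenyl in place of 3-chlorophenyl on a carbonyl carbon. Among the measured compounds shown here, no measured pair isolates this change, so the step is expected to be small, probably within the scatter, with a slight rise in the number if anything. Compound 3 is estimated at 1000 nM in this assay, within 250 nM to 4000 nM. The expected step is a 1.4-fold higher number from compound 1 to compound 3 (0.14 log units; within the scatter).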

Compound 3, concentration for 50% growth inhibition: 5140 nM
The estimate for compound 3 lay 5.1-fold (0.71 log units) below the measured number; measured number outside the range, above it.
By their numbers in this assay, from the lowest: compound 1; then compound 3; then compound 2.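

Moving the chlorine in this assay, from 3-chlorophenyl to 2-chlorophenyl on a carbonyl carbon, gives a 7.1-fold higher number from compound 1 to compound 3 (0.85 log units; beyond the scatter). This position therefore responds to chlorine placement alone, with the atoms unchanged, and of these two isomers 3-chlorophenyl gives the lower number. Nothing measured here explains the step.

On these data alone, whether a plain phenyl or a methoxyphenyl on this carbonyl carbon would hold the number of compound 1 remains open. So does the contribution of the trifluoromethyl group, which no single-place pair isolates.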